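A Small Swap in a Level Cytotoxicity Series

The compounds below may be only part of what the source reports. "The series", "measured", "known", "first", "only" and "open" are said of these compounds alone.

Of the compounds shown here, three that share one core have been measured in an ADME assay on MT4 cells (Homo sapiens) for cytotoxicity, read by MTT assay; on this read-out higher numbers stand for lower toxicity in this test and lower numbers for higher toxicity in this test. There, compound 1 (`CC(=O)c1ccc(NC(=O)CSc2nncnc2-c2cccc3ccccc23)c(Br)c1`) gives 133000 nM, compound 2 (`Cc1ccccc1NC(=O)CSc1nncnc1-c1cccc2ccccc12`) gives 158000 nM, and compound 3 (`Cc1ccc(NC(=O)CSc2nncnc2-c2cccc3ccccc23)c([N+](=O)[O-])c1`) gives 147000 nM. Compound 3 therefore stands within the usual scatter of both other compounds, so these numbers set no order among the three.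

The next compound to be tested is compound 4 (`O=C(CSc1nncnc1-c1cccc2ccccc12)Nc1ccccc1Br`). It differs from compound 3 at one place, with 2-bromophenyl in place of 4-methyl-2-nitrophenyl on an amide-type nitrogen.

Within the data shown here, three measured steps bear on this change, since each swaps the group at that same nitrogen. They are a 1.2-fold higher number from compound 1 to compound 2 (0.07 log units; within the scatter), a 1.1-fold higher number from compound 1 to compound 3 (0.04 log units; within the scatter) and a 1.1-fold lower number from compound 2 to compound 3 (0.03 log units; within the scatter). Among the measured compounds shown here, none of the three moves the number beyond the scatter, and no measured compound goes against this small set of results. For the measured compounds named here, still, no measured compound carries the 2-bromophenyl group itself, so the evidence is indirect.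

The expected result is a 1.0-fold lower number from compound 3 to compound 4 (0.01 log units; within the scatter), an estimated step that stays within the scatter. For compound 4 the estimated value in this assay is 145000 nM, with an expected range from 90000 nM to 230000 nM.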

Compound 4, half-maximal cytotoxic concentration: 87000 nM
The estimate for compound 4 lay 1.7-fold (0.22 log units) above the measured number; measured number outside the range, below it.
By their numbers in this assay, from the lowest: compounds 4, 1, 3 and 2 (each within the scatter of the next).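

Putting 2-bromophenyl on the amide-type nitrogen gives a 1.7-fold lower number from compound 3 to compound 4 (0.23 log units; within the scatter) in this assay, so a fourth group at this place still leaves the number inside the scatter. The same holds for the two simplest edits in the series, each confined to one aromatic carbon: bromo in place of methyl gives a 1.8-fold lower number from compound 2 to compound 4 (0.26 log units; within the scatter) and hydrogen in place of acetyl gives a 1.5-fold lower number from compound 1 to compound 4 (0.18 log units; within the scatter). These are the largest steps seen so far, yet none of them separates compound 4 from the other three, and no supporting evidence is available to explain where compound 4 falls.

Going by these compounds, all four compounds carry a substituted phenyl ring on this nitrogen, so it remains open whether an amine or a carboxylic acid on that ring, or a longer alkyl chain in place of the ring, would move the number beyond the scatter. Changes elsewhere also remain open, such as replacing the sulfur-containing link to the shared core or removing the amide hydrogen, since all four compounds keep both.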